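This account rests on a few compounds, and the source may have more. Where it says the series, first, only, none or still open, it means among the compounds named here.

In a functional assay on A549 cells (Homo sapiens) for cytotoxicity, read by MTT assay, with a stated time of 72 h (a higher number here means a weaker inhibitor, a lower number a stronger inhibitor), compound 3 (`COc1cc2ncnc(Nc3ccc(F)c(Cl)c3)c2cc1NC(=O)N/N=C/c1ccc(C#N)cc1`) gives 32200 nM, and compound 1 (`N#Cc1ccc(/C=N/NC(=O)Nc2cc3c(Nc4ccc(F)c(Cl)c4)ncnc3cc2O[C@H]2CCOC2)cc1`) gives 29100 nM. These two lie within the scatter of each other, with a 1.1-fold higher number from compound 1 to compound 3 (0.04 log units; within the scatter), and together they form the high end of the three numbers in the series. Compound 2 (`O=C(N/N=C/c1ccc(O)cc1O)Nc1cc2c(Nc3ccc(F)c(Cl)c3)ncnc2cc1O[C@H]1CCOC1`) gives 9360 nM, which is lower than the number for compound 3 by more than the scatter.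

Compound 4 (`COc1cc2ncnc(Nc3ccc(F)c(Cl)c3)c2cc1NC(=O)N/N=C/c1ccc(O)c(Br)c1`) has not been measured. It differs from compound 3 as follows: 3-bromo-4-hydroxyphenyl in place of 4-cyanophenyl on a carbon with a double bond to nitrogen. For the measured compounds named here, the nearest precedent is a 3.1-fold lower number from compound 1 to compound 2 (0.49 log units; beyond the scatter), a modest step beyond the scatter that also removes the 4-cyanophenyl from the same carbon. That step was seen with the oxolan-3-yl compounds, but a 1.1-fold higher number from compound 1 to compound 3 (0.04 log units; within the scatter) gives no sign that methyl in its place changes the number, so the precedent is carried over to compound 3. Going by the values given here, no measured compound carries bromine, and the entering group differs from that of compound 2, so the size of the step remains uncertain. A modest step of similar size toward a lower number is therefore expected, and the expected step is a 2.7-fold lower number from compound 3 to compound 4 (0.43 log units; beyond the scatter). The estimate for compound 4 is 12000 nM, with an expected range of 5000 nM to 27000 nM.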

Compound 4, half-maximal inhibitory concentration: 28600 nM
Beside the measured number, compound 4's estimate is 2.4-fold (0.38 log units) below it; the whole stated range lies below it.
By their numbers in this assay, from the lowest: compound 2; then compounds 4, 1 and 3 (each within the scatter of the next).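

In this assay the change at the carbon with a double bond to nitrogen gives a 1.1-fold lower number from compound 3 to compound 4 (0.05 log units; within the scatter), so on the methyl compounds 3-bromo-4-hydroxyphenyl and 4-cyanophenyl read alike. The earlier result at this place, a 3.1-fold lower number from compound 1 to compound 2 (0.49 log units; beyond the scatter), therefore does not extend to every hydroxyl-bearing phenyl that replaces 4-cyanophenyl, and compound 4 goes against any such pattern. No data at hand explain this result.

The two steps differ both in the entering group and in the group on the oxygen on the aromatic ring, so the compounds shown do not tell whether 2,4-dihydroxyphenyl would lower the number on the methyl compounds, or whether 3-bromo-4-hydroxyphenyl would leave it unchanged on the oxolan-3-yl compounds. Also open, as far as these compounds go, is how the number responds at this place to a phenyl carrying an amine or a carboxylic acid, or to a phenyl carrying bromine alone or hydroxyl alone, which would separate the two substituents of compound 4.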